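Swapping the methoxynitrophenyl for nitrophenyl: Vero cell toxicity

The compounds below may be only part of what the source reports. "The series", "measured", "known", "first", "only" and "open" are said of these compounds alone.

Compound 1 `COC(=O)c1cc(-c2cccc(NC(=O)c3ccc(/C=C/C(=O)c4ccccc4OC)cc3)c2)on1` gives > 40 ug/mL in an ADME assay on Vero cells (Chlorocebus sabaeus) for cytotoxicity, read by MTT assay, with a stated time of 72 h (on this read-out higher numbers stand for lower toxicity in this test and lower numbers for higher toxicity in this test), a limit of the assay rather than a number.
Compound 2 `COC(=O)c1cc(-c2cccc(NC(=O)c3ccc(/C=C/C(=O)c4ccc(OC)c(OC)c4)cc3)c2)on1` gives > 50 ug/mL in this assay, again a limit.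
Compound 3 `COC(=O)c1cc(-c2cccc(NC(=O)c3ccc(/C=C/C(=O)c4ccc(OC)c([N+](=O)[O-])c4)cc3)c2)on1` gives > 40 ug/mL in this assay, also a limit.

Compound 3 therefore stands only at a limit, shared with compound 1 at the limit of > 40 ug/mL in this assay, at which 2 of the 3 values shown sit, while compound 2 sits at the limit of > 50 ug/mL in this assay, at which 1 of the 3 values shown sits. The steps a step that the two limits leave unreadable from compound 1 to compound 2, a step that the two limits leave unreadable from compound 1 to compound 3 and a step that the two limits leave unreadable from compound 2 to compound 3 are all unreadable. The change to compound 4 `COC(=O)c1cc(-c2cccc(NC(=O)c3ccc(/C=C/C(=O)c4ccc([N+](=O)[O-])cc4)cc3)c2)on1` is 4-nitrophenyl in place of 4-methoxy-3-nitrophenyl on a carbonyl carbon. Among the measured compounds shown here, none of the measured steps gives a readable size, so no step beyond the scatter is expected in this assay; the expected step is a step that the limit leaves unreadable from compound 3 to compound 4. Compound 4 is estimated at 45 ug/mL, within 25 ug/mL to 80 ug/mL.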

Compound 4, half-maximal cytotoxic concentration: > 20 ug/mL
Compound 4 was reported as a limit; the forecaster's own chance of this, stated with the estimate: 80%; the middle value does not contradict the limit.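

Compound 4, like compound 1, compound 2 and compound 3, is reported only as a limit, so none of its steps to those compounds can be read. On these data alone, whether these four compounds differ at all in this assay stays open.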